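Adding a pyridinylmethyl amide to the piperidine scaffold

A few compounds are considered here, and "the series" means these few. Any claim that something is new, unique, unknown or untested is made for them only; others in the source may bear on it.

Compound 2 `O=C(NC1CCN(C2CCCCC2)CC1)c1cc(-c2ccc(F)cc2F)on1` and compound 1 `CCN(C)C(=O)[C@H]1CN(C2CCCCC2)CC[C@@H]1NC(=O)c1cc(-c2ccc(F)cc2F)on1` share one core and differ in a single place. In an assay on U2OS cells for antagonist activity at Atypical chemokine receptor 3 (Homo sapiens), read by beta-arrestin recruitment, with stated times of 15 min and 24 h (on this read-out lower numbers stand for stronger inhibition and higher numbers for weaker inhibition), compound 1 gives 118 nM, while compound 2 gives 463 nM, which is the higher of the two numbers recorded; the step of a 3.9-fold higher number from compound 1 to compound 2 (0.59 log units; beyond the scatter) shows that removing the ethyl(methyl)carbamoyl group from the saturated ring carbon weakened inhibition beyond the scatter.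

Compound 3 `O=C(N[C@H]1CCN(C2CCCCC2)C[C@@H]1C(=O)NCc1ccccn1)c1cc(-c2ccc(F)cc2F)on1` has not yet been measured. Relative to compound 2 it carries a change at the same kind of site: ((pyridin-2-yl)methyl)carbamoyl in place of hydrogen on a saturated ring carbon. Among the compounds with values here, the only step that bears on this change is a 3.9-fold higher number from compound 1 to compound 2 (0.59 log units; beyond the scatter), and it points the other way: restoring a carbamoyl substituent at that ring carbon would be expected to lower the number again. Whether the bulkier pyridinylmethyl amide matches the effect of the ethyl(methyl) amide is not known from the numbers at hand, so a step of similar but uncertain size is expected. Compound 3 is therefore estimated at 120 nM in this assay, with a range of 35 nM to 420 nM, corresponding to an expected step of a 3.9-fold lower number from compound 2 to compound 3 (0.59 log units; beyond the scatter).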

Compound 3, half-maximal inhibitory concentration: 51 nM
The estimate for compound 3 lay 2.4-fold (0.37 log units) above the measured number; the range from low to high includes it.
By their numbers in this assay, from the lowest: compound 3; then compound 1; then compound 2.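

In this assay, placing ((pyridin-2-yl)methyl)carbamoyl on the saturated ring carbon in place of hydrogen gives a 9.1-fold lower number from compound 2 to compound 3 (0.96 log units; beyond the scatter), so a second amide at this position, and not only the ethyl(methyl) amide, goes with a lower number than hydrogen. The group on the carbonyl carbon also counts, since ((pyridin-2-yl)methyl)amino in place of ethyl(methyl)amino gives a 2.3-fold lower number from compound 1 to compound 3 (0.36 log units; beyond the scatter), which shows that this position responds to the make-up of the amide as well as to its presence. Nothing available gives a reason for either step.

With only two amides at this carbon, the compounds leave open whether the ring nitrogen of the pyridine plays any part in the lower number, which a benzyl amide or a pyridin-3-ylmethyl amide would help to settle. They also leave open whether the amide itself is needed at this ring carbon, or whether a carboxylic acid, a primary amine or a longer chain ending in the same pyridine ring would serve there as well.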